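Two nucleosides measured, one furan analogue still to come

This account rests on a few compounds, and the source may have more. Where it says the series, first, only, none or still open, it means among the compounds named here.

Compound 1, `COc1ncnc2c1c(I)cn2[C@@H]1O[C@H](CO)[C@@H](O)[C@H]1O`: in a functional assay on CCRF-CEM cells (Homo sapiens), read by MTT assay, with a stated time of 72 h (a higher number here means a weaker inhibitor, a lower number a stronger inhibitor), compound 1 gives 1150 nM.
Compound 2, `Nc1nc2c(c(-c3ccccc3)cn2[C@@H]2O[C@H](CO)[C@@H](O)[C@H]2O)c(=O)[nH]1`: in this assay compound 2 gives only a limit, > 100000 nM.

Compound 2 therefore stands at the edge of what the assay can report, (the limit of > 100000 nM in this assay, at which 1 of the 2 values shown sits). Compound 3, `Nc1nc2c(c(-c3ccoc3)cn2[C@@H]2O[C@H](CO)[C@@H](O)[C@H]2O)c(=O)[nH]1`, differs from compound 2 in one place: furan-3-yl in place of phenyl on an aromatic carbon. Among the measured compounds shown here, no measured pair shows this change, so its size is unknown; with compound 2 already at the limit, the expected step from compound 2 to compound 3 in this assay is a number no higher from compound 2 to compound 3 (the limit leaves the size open), not beyond the scatter. Compound 3 is estimated at 100000 nM, between 30000 nM and 300000 nM, most likely again only a limit.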

Compound 3, half-maximal inhibitory concentration: 17900 nM
For compound 3 the middle estimate is 5.6-fold (0.75 log units) above the measured one, outside the stated range (below it).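

In this assay, furan-3-yl in place of phenyl on this aromatic carbon gives an at least 5.5-fold lower number from compound 2 to compound 3 (0.74 log units; beyond the scatter). This shows that the group at this position can move compounds on this core from the limit of the assay to a measurable value. Going by these compounds, the full size of the step stays unknown, because compound 2 has only a limit: the limit of > 100000 nM in this assay, at which 1 of the 3 values shown sits.

Still open, on these data alone, is whether this position accepts only aromatic rings, or whether a non-aromatic group such as an amine or a longer chain would also give a measurable value here.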